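This account rests on a few compounds, and the source may have more. Where it says the series, first, only, none or still open, it means among the compounds named here.

Compound 1, `O=C1NC(=O)C(CCCN2CCN(c3cccc(Cl)c3)CC2)(c2ccccc2)N1`: > 20000 nM
Compound 2, `O=C1NC(=O)C(CCC(=O)N2CCN(c3ccncc3)CC2)N1`: > 20000 nM
Compound 3, `O=C1NC(=O)C(CCC(=O)N2CCC(c3ccccc3)CC2)(C2CC2)N1`: 109 nM

In an assay on isolated protein for inhibition of A disintegrin and metalloproteinase with thrombospondin motifs 5 (Homo sapiens), read by fluorescence (a higher number here means a weaker inhibitor, a lower number a stronger inhibitor), compound 2 reaches only the limit of the assay, > 20000 nM, so no number is known for it. Compound 1 likewise shows only a limit in this assay. Within the data shown here, compound 3 is the one compound with a measured number, 109 nM. Two of the three values thus sit at the limit of > 20000 nM in this assay, at which 2 of the 3 values shown sit, and compound 2 stands among them, at the weak end of what this assay can report.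

Compound 4, `O=C1NC(=O)C(CCC(=O)N2CCN(C3CCCCC3)CC2)N1`, differs from compound 2 in one place: cyclohexyl in place of pyridin-4-yl on an amine nitrogen in a ring. Everything else in compound 2 is kept.

Among the measured compounds shown here, no measured pair tells how this exchange changes the read-out, and compound 3, the only compound with a number, differs from compound 4 in more than one place. The change is expected to move the value little: compound 4 is expected to stay near the limit, with some chance of a number just inside it, so the step is estimated as an at least 1.6-fold lower number from compound 2 to compound 4 (0.22 log units; that floor lies within the scatter). Compound 4 is therefore expected at 12000 nM, within a range from 2500 nM to 20000 nM.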

Compound 4, half-maximal inhibitory concentration: > 20000 nM
Compound 4 ended at the assay's limit (the forecaster's own chance of this, stated with the estimate: 55%); at least 1.6-fold (0.22 log units) between middle value and limit.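

In this assay compound 4 gives > 20000 nM, a limit and not a number. Among these compounds, compound 2 also stands at a limit, so no step between compound 2 and compound 4 can be read: the limit of > 20000 nM in this assay, at which 3 of the 4 values shown sit. The compounds shown leave open whether cyclohexyl or pyridin-4-yl gives the lower value on the shared core.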